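This account rests on a few compounds, and the source may have more. Where it says the series, first, only, none or still open, it means among the compounds named here.

For the measured compounds named here, in a functional assay on HEK293 cells for agonist activity at Nucleotide-binding oligomerization domain-containing protein 1 (Homo sapiens), read by spectrophotometry (on this read-out lower numbers stand for an effect already at smaller amounts and higher numbers for an effect only at larger amounts of compound), compound 2 `CCCCCCCCCCCC(=O)N[C@H](CCC(=O)N[C@@H](CCCCN)C(=O)O)C(=O)O` gives 0.57 nM; it is the only compound of the pair with a number in this assay. Compound 1 `CCCCCCCCCCCC(=O)N[C@H](CCC(=O)NC(CCCCC(=O)O)C(=O)O)C(=O)O` stops at the limit > 100 nM in this assay. Going by the values given here, the one measured step, an at least 170-fold lower number from compound 1 to compound 2 (2.24 log units; beyond the scatter), rests on a single limit (the limit of > 100 nM in this assay, at which 1 of the 2 values shown sits), so its true size is not known beyond its lower bound. Compound 3 `CCCCCCCCCCCC(=O)N[C@H](CCC(=O)NCCCC[C@H](N)C(=O)O)C(=O)O` differs from compound 2 by 5-amino-5-carboxypentyl in place of 5-amino-1-carboxypentyl on an amide-type nitrogen: the same atoms, joined so that the amine and the acid change ends of the chain. Among the compounds with values here, compound 1, which lacks the amine altogether, sits at the limit, and compound 2, with the amine on the end of the chain and the acid on the carbon attached to the amide nitrogen, is the potent one; compound 3 keeps both groups but moves them, and no measured step covers that rearrangement. The expectation for compound 3 is therefore a rise beyond the scatter in this assay, a 70-fold higher number from compound 2 to compound 3 (1.85 log units; beyond the scatter), though the size is uncertain. Compound 3 is expected to give 40 nM in this assay, between 3 nM and 500 nM.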

Compound 3, half-maximal effective concentration: 0.96 nM
The estimate for compound 3 lay 42-fold (1.62 log units) above the measured number; measured number outside the range, below it.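

In this assay, 5-amino-5-carboxypentyl in place of 5-amino-1-carboxypentyl on an amide-type nitrogen gives a 1.7-fold higher number from compound 2 to compound 3 (0.23 log units; within the scatter), so these two arrangements of the same atoms cannot be told apart here. This shows what the earlier pair could not: at this place, the amine and the acid can change ends of the chain without a change beyond the scatter, and the acid need not sit on the carbon attached to the amide nitrogen. The new arrangement also keeps the large step away from the group of compound 1, with an at least 100-fold lower number from compound 1 to compound 3 (2.01 log units; beyond the scatter), and that step has only a lower bound, as compound 1 stands at a limit: the limit of > 100 nM in this assay, at which 1 of the 3 values shown sits.

From the compounds shown here alone, it remains open what a side chain carrying the amine but no carboxylic acid, or the carboxylic acid but no amine on a chain of this kind, would give in this assay. Also open, going by these compounds, are the effects of a shorter or longer chain and of the opposite configuration at the carbon that carries the amine and the acid in compound 3.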